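Swapping the amide substituent: from an aryloxymethyl back toward a benzyl-type group

The source may hold more compounds than are shown below. What is called first, only, known or untested is meant among the compounds shown, and "the series" means these compounds.

Measured compounds:
- compound 1, `Cc1ccc(CC(C)C(=O)N2CCN(c3ccc(C(F)(F)F)cc3[C@@H](N)CC(C)C)CC2)cc1C`, 240 nM
- compound 2, `CC(C)C[C@H](N)c1cc(C(F)(F)F)ccc1N1CCN(C(=O)CNc2ccccc2)CC1`, 3600 nM
- compound 3, `CC(C)C[C@H](N)c1cc(C(F)(F)F)ccc1N1CCN(C(=O)COc2cccc(Cl)c2Cl)CC1`, 2500 nM

All three share one core and differ only in the group on the carbonyl carbon of the amide. In an assay on HEK293 cells for displacement of a labelled ligand from Melanocortin receptor 4 (Homo sapiens) (on this read-out lower numbers stand for stronger inhibition and higher numbers for weaker inhibition), compound 3 gives 2500 nM, the second highest of the three numbers; its nearest neighbour is compound 2, and that gap is a 1.4-fold lower number from compound 2 to compound 3 (0.16 log units; within the scatter). The distance to compound 1 is larger: a 10-fold higher number from compound 1 to compound 3 (1.02 log units; beyond the scatter).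

Compound 4, `Cc1cc(CC(C)C(=O)N2CCN(c3ccc(C(F)(F)F)cc3[C@@H](N)CC(C)C)CC2)ccc1Cl`, is not yet measured. Its difference from compound 3 is 1-(4-chloro-3-methylbenzyl)ethyl in place of (2,3-dichlorophenoxy)methyl on a carbonyl carbon.

Within the data shown here, two measured steps bear on this. The step of a 10-fold higher number from compound 1 to compound 3 (1.02 log units; beyond the scatter) shows what happens when a 1-(3,4-dimethylbenzyl)ethyl is replaced by (2,3-dichlorophenoxy)methyl, and a 15-fold higher number from compound 1 to compound 2 (1.18 log units; beyond the scatter) shows a similarly large loss for another small replacement. The change to compound 4 runs the other way, reinstating a 1-(aryl-benzyl)ethyl group of the same kind as in compound 1. A large drop in the number is therefore expected, of about a 10-fold lower number from compound 3 to compound 4 (1.00 log units; beyond the scatter), because a 10-fold higher number from compound 1 to compound 3 (1.02 log units; beyond the scatter) was of that size. The estimate for compound 4 is 250 nM, expected within 100 nM to 650 nM.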

Compound 4, inhibition constant: 71 nM
The estimate for compound 4 lay 3.5-fold (0.55 log units) above the measured number; the whole stated range lies above it.
By their numbers in this assay, from the lowest: compound 4; then compound 1; then compounds 3 and 2 (each within the scatter of the next).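

In this assay the 1-(4-chloro-3-methylbenzyl)ethyl group on the carbonyl carbon gives a 35-fold lower number from compound 3 to compound 4 (1.55 log units; beyond the scatter) and, against the anilinomethyl group, a 51-fold lower number from compound 2 to compound 4 (1.71 log units; beyond the scatter) in a second large step. So a second group of this branched benzyl type also reads far lower than both non-benzyl groups, and the pattern no longer rests on compound 1 alone. The aromatic ring of this group also matters, as chloro in place of methyl on an aromatic carbon gives a 3.4-fold lower number from compound 1 to compound 4 (0.53 log units; beyond the scatter) as a modest step beyond the scatter, and nothing shown here explains any of these differences.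

On these data alone, whether other groups on that aromatic ring, such as fluoro, methoxy or nitrile, would lower the number further remains open. So does the effect of a carboxylic acid or a longer chain on the same carbonyl carbon.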